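Lengthening the Ester Chain from Ethoxy to Propoxy

The source may report more compounds than this note shows. Statements on the series, on what has been measured and on what is new or still open speak of the compounds shown alone.

Going by the values given here, in a functional assay on A549 cells (Homo sapiens) for antiproliferative activity, read by MTT assay, with a stated time of 48 h (a lower number here means a stronger inhibitor of growth, a higher number a weaker inhibitor of growth), compound 2 `CCOC(=O)N1N=C(c2ccc(OC)cc2)CC1c1cc(OC)c(OC)c(OC)c1` gives 4690 nM, the only exact number so far. Compound 1 `CCCOC(=O)N1N=C(c2cccc(OC)c2)CC1c1cc(OC)c(OC)c(OC)c1` is recorded as a limit, > 10000 nM. Compound 3 `CCCOC(=O)N1N=C(c2ccc(OC)cc2)CC1c1cc(OC)c(OC)c(OC)c1` differs from compound 2 by methyl in place of hydrogen on a saturated chain carbon, two bonds along the chain from an oxygen next to a carbonyl group, with methyl in place of hydrogen on a saturated chain carbon, which turns ethoxy to propoxy. Among the compounds with values here, no measured pair shows this change alone. A modest weakening of growth inhibition in this assay is expected, estimated as a 1.3-fold higher number from compound 2 to compound 3 (0.11 log units; within the scatter), and it may stay within the scatter. For compound 3 the estimated value is 6000 nM, with an expected range of 2200 nM to 16000 nM.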

Compound 3, concentration for 50% growth inhibition: > 10000 nM
Compound 3 was reported as a limit; the forecaster's own chance of this, stated with the estimate: 30%; at least 1.6-fold (0.22 log units) between middle value and limit.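

In this assay, going by these compounds alone, turning ethoxy into propoxy gives an at least 2.1-fold higher number from compound 2 to compound 3 (0.32 log units; beyond the scatter), so a single methyl on this saturated chain carbon, two bonds along the chain from an oxygen next to a carbonyl group, weakens growth inhibition beyond the scatter, which no earlier pair could show. The step between compound 1 and compound 3 cannot be read, as both values are limits. The result for compound 3 is itself only a limit: the limit of > 10000 nM in this assay, at which 2 of the 3 values shown sit.

From the compounds shown here alone, how far growth inhibition falls with propoxy remains open. So does how a methoxy, a butoxy or a longer chain would read at this place.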